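The source may hold more compounds than are shown below. What is called first, only, known or untested is meant among the compounds shown, and "the series" means these compounds.

Of the compounds shown here, three have so far been tested in an ADME assay on Huh-7 cells (Homo sapiens) for cytotoxicity, read by MTT assay, with a stated time of 72 h; on this read-out lower numbers stand for higher toxicity in this test and higher numbers for lower toxicity in this test. Compound 1 `COc1ccc(CNC(=O)/C=C/c2c[nH]c3ccccc23)cc1OC` gives a true number, 89500 nM. Compound 2 `C/C(=C\c1c[nH]c2ccccc12)C(=O)O` gives only a limit of the assay, > 100000 nM. Going by these compounds, compound 3 `C/C(=C\c1c[nH]c2ccccc12)C(N)=O` also gives only a limit, > 10000 nM, so its exact place on the scale is unknown.

Among the compounds with values here, the one measured change nearby is a step that the two limits leave unreadable from compound 2 to compound 3, with amino in place of hydroxy on a carbonyl carbon, so it offers no size to carry forward. The next change leads to compound 4 `C/C(=C\c1c[nH]c2ccccc12)C(=O)NCCN(C)C` and puts 2-(dimethylamino)ethyl in place of hydrogen on an amide-type nitrogen.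

Within the data shown here, the only firm guide is compound 1 at 89500 nM, which also carries a group on its amide nitrogen. On that basis, compound 4 is expected to remain weakly toxic in this assay, with no sharp move in either direction. The expected change is a step that the limit leaves unreadable from compound 3 to compound 4, though this size is only loosely estimated. The estimate for compound 4 is 40000 nM, expected to lie between 12000 nM and 100000 nM.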

Compound 4, half-maximal cytotoxic concentration: > 100000 nM
Compound 4: only a limit was reported; the forecaster's own chance of this, stated with the estimate: 45%; at least 2.5-fold (0.39 log units) between middle value and limit.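

Compound 4 gives only a limit, as do compound 2 and compound 3, so the steps from compound 3 to compound 4 and from compound 2 to compound 4 cannot be read. The compounds shown leave open where these three truly lie on the scale, and whether 2-(dimethylamino)ethyl on the amide-type nitrogen changes toxicity at all.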